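The source may report more compounds than this note shows. Statements on the series, on what has been measured and on what is new or still open speak of the compounds shown alone.

Working notes on the series in an ADME assay on RD cells (Homo sapiens) for cytotoxicity; a lower number here means that less compound is tolerated, a higher number that more compound is tolerated. Compound 1 `Cc1ccccc1NC(=S)N/N=C1\C(=O)Nc2ccccc21` returns only a limit of the assay in this assay, > 25000 nM. Compound 2 `COc1ccccc1NC(=S)N/N=C1\C(=O)Nc2ccccc21` likewise comes back as a limit, > 25000 nM. Compound 3 `COc1cccc(NC(=S)N/N=C2\C(=O)Nc3ccccc32)c1` also gives a limit, > 25000 nM. Among the compounds with values here, the one step between neighbours that differ in a single place, from compound 1 to compound 2 with a step that the two limits leave unreadable from compound 1 to compound 2, cannot be sized because of the limit of > 25000 nM in this assay, at which 3 of the 3 values shown sit. Compound 3 stands in the same position, so no direction of change is readable anywhere in the set so far.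

Compound 4 `O=C1Nc2ccccc2/C1=N/NC(=S)Nc1ccc(F)cc1` is not yet measured. Its change from compound 1 is 4-fluorophenyl in place of 2-methylphenyl on an amide-type nitrogen. Within the data shown here, no measured step bears on this exchange, and the single measured step is itself unreadable, so nothing here sizes an effect of the change in this assay. Among the measured compounds shown here, with every value so far resting at the limit, compound 4 is expected to rest there too, the expected step from compound 1 to compound 4 being a step that the limit leaves unreadable from compound 1 to compound 4. The estimate for compound 4 is 30000 nM, spanning 18000 nM to 60000 nM.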

Compound 4, half-maximal cytotoxic concentration: > 25000 nM
Compound 4: no number, only a limit; the forecaster's own chance of this, stated with the estimate: 85%; the middle value lies beyond the limit too.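

Compound 4 also returns only a limit of the assay in this assay, > 25000 nM, so its step from compound 1 cannot be read: the limit of > 25000 nM in this assay, at which 4 of the 4 values shown sit. The compounds shown leave open where cytotoxicity begins for any of them, and whether exchanging the group on the amide-type nitrogen changes it.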